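This account rests on a few compounds, and the source may have more. Where it says the series, first, only, none or still open, it means among the compounds named here.

Working notes on the series.

Of the compounds shown here, two carry a number so far. Compound 1 `CC1(c2nc(-c3ccc(CNC(=O)[C@H]4NCC[C@@H]4O)cc3)no2)CCCCC1` gives 210 nM in an assay on isolated protein for inhibition of sphingosine kinase 1 (Homo sapiens) (a higher number here means a weaker inhibitor, a lower number a stronger inhibitor), and stands at the lowest number of the two. Compound 2 `CCCCCCCc1nnc(-c2ccc(CNC(=O)[C@H]3NCC[C@@H]3O)cc2)o1` gives 2200 nM in this assay, a higher number than that of compound 1 and well beyond the scatter of repeated runs. The two differ in more than one place, so the gap between them is not tied to any single change.

Compound 3 `O=C(NCc1ccc(-c2noc(C3CCCCCC3)n2)cc1)[C@H]1NCC[C@@H]1O` has not been measured yet. Within the data shown here, it keeps the shared core of compound 1 and changes only one group: cycloheptyl in place of 1-methylcyclohexyl on an aromatic carbon. The two compounds hold the same atoms, joined differently; a ring grows by one carbon and loses its methyl. Among the measured compounds shown here, with no pair of measured compounds that differ in one place, no step of this kind is known, and the expected step of a 1.4-fold higher number from compound 1 to compound 3 (0.15 log units; within the scatter) is small, with no direction that can be held beyond the scatter. Compound 3 is accordingly estimated at 300 nM, within 100 nM to 900 nM in this assay.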

Compound 3, half-maximal inhibitory concentration: 620 nM
Beside the measured number, compound 3's estimate is 2.1-fold (0.32 log units) below it, within the range that was stated.
By their numbers in this assay, from the lowest: compound 1; then compound 3; then compound 2.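

Among these compounds, the pair compound 1 and compound 3 is the first to differ in one place, and so gives the first reading at this aromatic carbon of the five-membered aromatic ring. In this assay, cycloheptyl in place of 1-methylcyclohexyl gives a 3.0-fold higher number from compound 1 to compound 3 (0.47 log units; beyond the scatter), a modest step, but one beyond the scatter. Both groups have 7 heavy atoms, all carbon, with no hydrogen-bond donors or acceptors and no net charge, so these counts do not separate them, yet the number still shifts when the same atoms are joined differently, and no measurement at hand bears on the reason.

The step combines two changes, a ring larger by one carbon and the loss of the methyl, and the pair cannot assign it to either one; a plain cyclohexyl or a 1-methylcycloheptyl group at this position would separate them. From the compounds shown here alone, it also remains open how a group of another kind at this position, such as an amine, a carboxylic acid or an open carbon chain, would read on the core of compound 1.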